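Swapping Quinoline for Cyanophenyl on an Adenosine Hydrazone

This account rests on a few compounds, and the source may have more. Where it says the series, first, only, none or still open, it means among the compounds named here.

Of the compounds shown here, two built on one shared core have so far been tested in an assay on CHO-K1 cells for displacement of a labelled ligand from adenosine receptor A1 (Homo sapiens), read by scintillation counting, with a stated time of 60 min; on this read-out higher numbers stand for weaker inhibition and lower numbers for stronger inhibition. Compound 1 `Nc1nc(N/N=C/c2ccc(-c3ccc(Br)cc3)o2)nc2c1ncn2[C@@H]1O[C@H](CO)[C@@H](O)[C@H]1O` carries one aromatic arm on the hydrazone carbon, and in this assay compound 1 gives 4.5 nM. Compound 2 `Nc1nc(N/N=C/c2ccc3ncccc3c2)nc2c1ncn2[C@@H]1O[C@H](CO)[C@@H](O)[C@H]1O` carries a quinolin-6-yl arm at the same position, and in this assay compound 2 gives 9.8 nM. Compound 2 therefore has the higher of the two numbers, which means weaker binding than compound 1, and the gap between them lies beyond the usual scatter of repeated measurements.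

Compound 3 `N#Cc1ccccc1/C=N/Nc1nc(N)c2ncn([C@@H]3O[C@H](CO)[C@@H](O)[C@H]3O)c2n1` has not yet been measured. It differs from compound 2 in a single place: 2-cyanophenyl in place of quinolin-6-yl on a carbon with a double bond to nitrogen. Two aromatic rings give way to one ring carrying a nitrile, so the arm becomes smaller and loses its ring nitrogen. Going by the values given here, no measured pair shows this exact change, so any forecast rests on compound 2 alone. The expectation is a modest move toward weaker binding, a step of about a 2.6-fold higher number from compound 2 to compound 3 (0.41 log units; beyond the scatter). Compound 3 is thus estimated at 25 nM, with a likely range from 6 nM to 100 nM.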

Compound 3, inhibition constant: 2.9 nM
Beside the measured number, compound 3's estimate is 8.6-fold (0.94 log units) above it; the whole stated range lies above it.
By their numbers in this assay, from the lowest: compounds 3 and 1 (each within the scatter of the next); then compound 2.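

In this assay, the arm on the carbon with a double bond to nitrogen can lose a whole aromatic ring without any loss of binding: replacing quinolin-6-yl with 2-cyanophenyl gives a 3.4-fold lower number from compound 2 to compound 3 (0.53 log units; beyond the scatter) and lies beyond the usual scatter. For this pair, then, the second ring and the ring nitrogen of quinolin-6-yl are not required for strong binding, and a smaller arm with a single carbon ring carrying a nitrile does better. The number of hydrogen-bond acceptors stays the same across the change, but nothing measured here explains why the number falls.

Two things change together in this swap, the ring system and the arrival of the nitrile, so this single step cannot separate their contributions. A plain phenyl arm would show what the single ring does without the nitrile, and a 2-methoxyphenyl arm would show whether another group can take the place of the nitrile on that ring.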